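This account rests on a few compounds, and the source may have more. Where it says the series, first, only, none or still open, it means among the compounds named here.

Measured compounds in an assay on isolated protein for binding affinity to corticotropin-releasing factor receptor 1 (Homo sapiens); a higher number here means a weaker inhibitor, a lower number a stronger inhibitor:

compound 1 `CCCN(Cc1ccccc1)c1cc(C)nc2c(-c3ncc(C(F)(F)F)cc3Cl)c(C)nn12` gives 1.7 nM
compound 2 `CCCN(CC1CC1)c1cc(C)nc2c(-c3ncc(Cl)cc3Cl)c(C)nn12` gives 3.9 nM
compound 3 `CCCN(CCC)c1cc(C)nc2c(-c3ncc(N(CC)CC)cc3C)c(C)nn12` gives 13 nM

Compound 3 has the highest of the three numbers in this assay; the nearest is compound 2, whose number is lower by an amount beyond the scatter, and the furthest is compound 1, lower still and also beyond the scatter. Among the compounds with values here, no step between two measured compounds differing in one place is available, so the series gives no directly comparable pair.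

Compound 4 `CCCN(CCC)c1cc(C)nc2c(-c3ncc(F)cc3C)c(C)nn12` is the unmeasured analogue of compound 3. The change is fluoro in place of diethylamino on an aromatic carbon. Compounds 1 and 2 carry small groups at the corresponding place and both have lower numbers than compound 3, but each also differs elsewhere, so this is only a loose pointer. A modest step toward a lower number is expected in this assay. The step from compound 3 to compound 4 is estimated at a 1.9-fold lower number from compound 3 to compound 4 (0.27 log units; within the scatter). Compound 4 is expected to give about 7 nM, in a range from 2.5 nM to 25 nM.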

Compound 4, inhibition constant: 19 nM
Estimate against measurement, compound 4: 2.7-fold (0.43 log units) below, and the stated range covers the measured number.
By their numbers in this assay, from the lowest: compound 1; then compound 2; then compounds 3 and 4 (each within the scatter of the next).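

In this assay, fluoro in place of diethylamino on this aromatic carbon gives a 1.5-fold higher number from compound 3 to compound 4 (0.16 log units; within the scatter), so this pair cannot be told apart. At this place, two atoms from the ring nitrogen, a group of 5 heavy atoms and one of 1 heavy atom therefore give no readable difference, and the hydrogen-bond acceptor lost with diethylamino leaves no readable mark on the number. Nothing on hand bears on why these two numbers sit so close.

On these data alone, whether the same holds for a carboxylic acid, a primary amine or a methoxy group at this place remains open. Within the data shown here, also open is whether the flat result carries over when the dipropylamino group on the shared core is changed, since no pair here tests that.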